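Cytotoxicity unchanged across three substituents on the shared core

A few compounds are considered here, and "the series" means these few. Any claim that something is new, unique, unknown or untested is made for them only; others in the source may bear on it.

Compound 1 `COc1ccccc1Oc1ccc2c(NCCCNCc3ccco3)ccnc2c1`: in an ADME assay on HepG2 cells (Homo sapiens) for cytotoxicity, read by luminescence, CellTiter-Glo and ATP content, with a stated time of 72 h (on this read-out lower numbers stand for an effect already at smaller amounts and higher numbers for an effect only at larger amounts of compound), compound 1 gives 6500 nM.
Compound 2 `c1ccc(-c2ccc3c(NCCCNCc4ccco4)ccnc3c2)cc1`: in this assay compound 2 gives 5920 nM.
Compound 3 `Cc1cc(C)cc(Cc2ccc3c(NCCCNCc4ccco4)ccnc3c2)c1`: in this assay compound 3 gives 6270 nM.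

The three measured compounds share one core and differ only in the group on an aromatic carbon of that core. In this assay their numbers sit close together: a 1.1-fold lower number from compound 1 to compound 2 (0.04 log units; within the scatter), a 1.0-fold lower number from compound 1 to compound 3 (0.02 log units; within the scatter) and a 1.1-fold higher number from compound 2 to compound 3 (0.02 log units; within the scatter) all lie within the scatter, so compound 3 cannot be set apart from compound 1 or compound 2 on these numbers.

Compound 4 `COc1ccc(-c2ccc3c(NCCCNCc4ccco4)ccnc3c2)cc1` carries the next change: 4-methoxyphenyl in place of 3,5-dimethylbenzyl on an aromatic carbon. The step that bears most on it is the one in which a benzyl-type group replaced a phenyl, a 1.1-fold higher number from compound 2 to compound 3 (0.02 log units; within the scatter), which did not move the number beyond the scatter, and the exchanges leading into compound 3, a 1.0-fold lower number from compound 1 to compound 3 (0.02 log units; within the scatter), were flat as well. No step beyond the scatter is therefore expected in this assay, and the estimated change is a 1.0-fold lower number from compound 3 to compound 4 (0.00 log units; within the scatter). Compound 4 is expected to give about 6200 nM, with a range from 3000 nM to 12500 nM.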

Compound 4, half-maximal effective concentration: 6000 nM
Compound 4: the middle estimate sits 1.0-fold (0.01 log units) above what was measured; low and high end bracket the measured number.
By their numbers in this assay, from the lowest: compounds 2, 4, 3 and 1 (each within the scatter of the next).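

Methoxy in place of hydrogen on the phenyl group gave a 1.0-fold higher number from compound 2 to compound 4 (0.01 log units; within the scatter) in this assay, so substitution on that ring did not separate the two compounds. The exchange of 3,5-dimethylbenzyl, with no hydrogen-bond acceptor, for 4-methoxyphenyl, with one, gave a 1.0-fold lower number from compound 3 to compound 4 (0.02 log units; within the scatter), and 4-methoxyphenyl in place of 2-methoxyphenoxy gave a 1.1-fold lower number from compound 1 to compound 4 (0.03 log units; within the scatter), so all the groups shown at this aromatic carbon remain indistinguishable on this read-out. No independent measurement is available to explain this sameness.

As far as these compounds go, whether an amine or a carboxylic acid at this aromatic carbon would give a number beyond the scatter of these four remains open. The compounds also all keep the rest of the shared core unchanged, so how a change elsewhere in the molecule would register in this assay is left open too.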